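The source may hold more compounds than are shown below. What is called first, only, known or untested is meant among the compounds shown, and "the series" means these compounds.

Compound 1 `COC(=O)Nc1cc(-c2ccc(OC[C@@](C)(N)CC(C)C)c(C)c2)ccn1`: 75%
Compound 2 `COC(=O)Nc1cc(-c2ccc(OC[C@@](C)(N)CC(C)C)c(F)c2)ccn1`: 71%

Among the measured compounds shown here, in an ADME assay on microsomes from liver (Mus musculus) for metabolic stability, read by LC-MS, using NADPH, with a stated time of 10 min, tested at 0.5 uM (on this read-out higher numbers stand for a more stable compound and lower numbers for a less stable compound), compound 1 stands at 75%, and the only other measured number, that of compound 2, lies within the usual scatter of it. Compound 3 `COC(=O)Nc1cc(-c2ccc(OC[C@@](C)(N)CC(C)C)c(C)c2C)ccn1` keeps the core of compound 1 and carries one change, methyl in place of hydrogen on an aromatic carbon, ortho to a methyl group: methyl in place of hydrogen on an aromatic carbon.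

For the measured compounds named here, only one measured step bears on this change, the fluoro in place of methyl on an aromatic carbon, and it is a loose guide. It concerns the same ring but a different carbon, and it exchanges one group for another instead of replacing a hydrogen. Going by the values given here, no measured step shows methyl in place of hydrogen. The sole reference is small, a number 4 percentage points lower from compound 1 to compound 2 (within the scatter), so only a small change is expected here, with a slight lean downward and nothing beyond the scatter.

The expected step in this assay is a number 4 percentage points lower from compound 1 to compound 3 (within the scatter). Compound 3 is estimated at 71%, with an expected range from 56% to 85%.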

Compound 3, percent of the compound remaining: 70%
The estimate for compound 3 lay 1 percentage points above the measured number, and the stated range covers the measured number.
By their numbers in this assay, from the lowest: compounds 3, 2 and 1 (each within the scatter of the next).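

In this assay, methyl in place of hydrogen on an aromatic carbon, ortho to a methyl group, gives a number 5 percentage points lower from compound 1 to compound 3 (within the scatter), so this step of one added heavy atom stays within the scatter. Among the compounds shown here, the earlier pair showed only fluoro exchanged for methyl on a different carbon of the same ring, whereas compound 3 is the first to show a hydrogen of this ring replaced, and at this position the added methyl leaves the percent of compound remaining within the scatter of compound 1. Nothing available explains why this step stays so small.

From the compounds shown here alone, what remains open is whether a larger or different group on this carbon, such as an ethyl group, a methoxy group or an amine, would also stay within the scatter, since methyl is the only replacement for hydrogen here. Also open is whether the same methyl would give a similar step alongside the fluoro of compound 2, because the compounds shown place it only alongside the methyl of compound 1.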